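The source may report more compounds than this note shows. Statements on the series, on what has been measured and on what is new or still open speak of the compounds shown alone.

In an ADME assay on MT4 cells (Homo sapiens) for cytotoxicity, read by MTT assay, with a stated time of 5 days (a lower number here means that less compound is tolerated, a higher number that more compound is tolerated), three compounds that share one core have been measured. Compound 1 `Nc1nc(-c2ccc(F)cc2)cc(-c2ccccc2O)n1` gives 67500 nM. Compound 3 `Cc1cccc(-c2cc(-c3ccccc3O)nc(N)n2)c1` gives 13000 nM, the lowest of the two numbers available; its nearest neighbour among them is compound 1, with a 5.2-fold lower number from compound 1 to compound 3 (0.72 log units; beyond the scatter) accompanying 3-methylphenyl in place of 4-fluorophenyl on an aromatic carbon. For compound 2 `Nc1nc(-c2ccc(Cl)cc2)cc(-c2ccccc2O)n1` the result, > 74700 nM, is a limit of the assay and not a number, since compound 2 reaches (the limit of > 74700 nM in this assay, at which 1 of the 3 values shown sits). Seen from that limit, an at least 5.7-fold lower number from compound 2 to compound 3 (0.75 log units; beyond the scatter) accompanies 3-methylphenyl in place of 4-chlorophenyl on an aromatic carbon, while an at least 1.1-fold higher number from compound 1 to compound 2 (0.04 log units; that floor lies within the scatter) accompanies chloro in place of fluoro on an aromatic carbon.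

Compound 4 `COc1cccc(-c2cc(-c3ccccc3O)nc(N)n2)c1` is the next one to be measured. It differs from compound 3 by methoxy in place of methyl on an aromatic carbon. Going by the values given here, none of the measured steps swaps a methyl for a methoxy: the two large steps each exchanged one substituted phenyl ring for another, and the halogen exchange stayed within the scatter. Among the compounds with values here, with no direct precedent, compound 4 is expected to show no step beyond the scatter, so the estimated step is a 1.4-fold higher number from compound 3 to compound 4 (0.14 log units; within the scatter). For compound 4 in this assay the estimate is 18000 nM, expected to lie between 7000 nM and 50000 nM.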

Compound 4, half-maximal cytotoxic concentration: > 78300 nM
Compound 4: a limit, no number; the forecaster's own chance of this, stated with the estimate: 10%; at least 4.3-fold (0.63 log units) between middle value and limit.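

In this assay, methoxy in place of methyl on an aromatic carbon, meta to a large group, goes with an at least 6.0-fold higher number from compound 3 to compound 4 (0.77 log units; beyond the scatter). The earlier steps shown here beyond the scatter each exchanged one whole substituted phenyl ring for another, whereas this pair shows that changing a single group at this place is enough to move the number beyond the scatter, and that the low number of compound 3 does not follow simply from having a group here, since compound 4 carries one at the same place. The result for compound 4 is a limit of the assay and not a number, so the step has a floor but no known full size: the limit of > 78300 nM in this assay, at which 1 of the 4 values shown sits.

The compounds shown leave open whether the oxygen of the methoxy group or the larger size of the group goes with this difference; a hydroxy group or an ethyl chain at this place would help to separate the two. They also leave open whether the same exchange would give a similar step elsewhere on the shared core.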